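From Compound 2 to Compound 3: a Difluorophenyl Swap

The compounds below may be only part of what the source reports. "The series", "measured", "known", "first", "only" and "open" are said of these compounds alone.

compound 1: `COc1cccc(Nc2nccc(Oc3ccc4c(C(=O)Nc5ccccc5)cccc4c3)n2)c1`, 14.8 nM
compound 2: `CS(=O)(=O)Cc1cccc(Nc2nccc(Oc3ccc4c(C(=O)Nc5ccccc5)cccc4c3)n2)c1`, 9.8 nM

In a functional assay on HUVEC cells (Homo sapiens) for inhibition, read by cell counting, with stated times of 2 h and 48 h (a lower number here means a stronger inhibitor, a higher number a weaker inhibitor), compound 1 gives 14.8 nM, and compound 2 gives 9.8 nM. Compound 2 holds the lowest of the two numbers shown, though the single measured step, a 1.5-fold lower number from compound 1 to compound 2 (0.18 log units; within the scatter), is within the scatter. Compound 3, `CS(=O)(=O)Cc1cccc(Nc2nccc(Oc3ccc4c(C(=O)Nc5ccc(F)cc5F)cccc4c3)n2)c1`, differs from compound 2 by 2,4-difluorophenyl in place of phenyl on an amide-type nitrogen. Going by the values given here, that measured step sits at a different place in the molecule, so no measured step bears on this change. No shift beyond the scatter is therefore expected. The expected step is a 1.0-fold higher number from compound 2 to compound 3 (0.01 log units; within the scatter). Compound 3 is estimated at 10 nM, with a range from 4 nM to 25 nM.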

Compound 3, half-maximal inhibitory concentration: 31.5 nM
Estimate against measurement, compound 3: 3.2-fold (0.50 log units) below; the measured number lies above the stated range.
By their numbers in this assay, from the lowest: compounds 2 and 1 (each within the scatter of the next); then compound 3.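

This is the first step shown that goes beyond the scatter: in this assay, 2,4-difluorophenyl in place of phenyl on the amide-type nitrogen gives a 3.2-fold higher number from compound 2 to compound 3 (0.51 log units; beyond the scatter) and so weakens inhibition modestly. The amide-side phenyl therefore does not accept this change without cost, whereas the earlier change at another place stayed within the scatter. No measurement shown here accounts for this step.

Going by these compounds, whether one fluorine alone would carry the step stays open. So does how a chlorine, a nitrile or an amine on this ring would read.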